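Chain Length and Cytotoxicity in a Cyanoguanidine Series

The compounds below may be only part of what the source reports. "The series", "measured", "known", "first", "only" and "open" are said of these compounds alone.

Compound 1 `N#C/N=C1\N(CCCCCCCOc2ccc(Cl)cc2)C(=O)CN1c1ccncc1`: 926 nM
Compound 2 `CC1C(=O)N(CCCCCOc2ccc(Cl)cc2)/C(=N\C#N)N1c1ccncc1`: 1780 nM
Compound 3 `N#C/N=C1\N(CCCCCOc2ccc(Cl)cc2)C(=O)CCN1c1ccncc1`: 3120 nM

In a functional assay on NUGC cells (stomach, Homo sapiens) for cytotoxicity (a lower number here means a stronger inhibitor, a higher number a weaker inhibitor), compound 3 gives 3120 nM, the highest of the three numbers. Its gap to compound 2 lies within the scatter of this assay, so the two cannot be told apart; its gap to compound 1 lies beyond the scatter, so compound 1 is the clearer inhibitor of the set.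

Compound 4 `N#C/N=C1\N(CCCCCCOc2ccc(Cl)cc2)C(=O)CCN1c1ccncc1` has not yet been measured. It differs from compound 3 by a single change: (4-chlorophenoxy)methyl in place of 4-chlorophenoxy on a saturated chain carbon, five bonds along the chain from an amide-type nitrogen in a ring. Going by the values given here, with no measured pair showing this exact change, the expectation rests on the set as a whole, where compound 1, which carries the longest chain, gives the lowest number. The step of a 1.4-fold lower number from compound 3 to compound 4 (0.15 log units; within the scatter) is therefore expected to be small and downward, and may well stay within the scatter. The estimate for compound 4 is 2200 nM, with a range from 900 nM to 5000 nM.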

Compound 4, half-maximal inhibitory concentration: 288 nM
Compound 4: middle estimate off by 7.6-fold (0.88 log units), on the high side; the whole stated range lies above it.
By their numbers in this assay, from the lowest: compound 4; then compounds 1, 2 and 3 (each within the scatter of the next, the first and the last beyond it).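

In this assay, replacing 4-chlorophenoxy with (4-chlorophenoxy)methyl on a saturated chain carbon, five bonds along the chain from an amide-type nitrogen in a ring, gives an 11-fold lower number from compound 3 to compound 4 (1.03 log units; beyond the scatter). The group grows only from 8 to 9 heavy atoms, yet the step is large, so potency at this position can depend strongly on chain length.

From the compounds shown here alone, a longer chain on this same core could continue the drop or reverse it, and an amine in place of the chlorophenoxy end remains untested here. No measurement shown here explains the size of the step.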